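Five-Membered Ring Swap on a Shared Core: Solubility Outlook

The compounds below may be only part of what the source reports. "The series", "measured", "known", "first", "only" and "open" are said of these compounds alone.

Compound 1, `CC(C)C(c1ccc(-c2ccc3cccc(F)c3c2)[nH]c1=O)N1CCCCC1=O`, gives 23100 nM in a physicochemical assay for solubility, in phosphate buffer, measured as kinetic solubility; a higher number here means a more soluble compound, a lower number a less soluble compound.
Compound 2, `CC(C)C(c1ccc(-c2ccc3cccc(F)c3c2)[nH]c1=O)N1CCN/C1=N\C#N`, gives 25200 nM in this assay.

Within the data shown here, compound 2 has the highest of the two numbers measured so far, but its nearest neighbour is compound 1, and the step of a 1.1-fold higher number from compound 1 to compound 2 (0.04 log units; within the scatter) lies within the scatter, so the two compounds cannot be told apart on solubility.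

Compound 3, `Cc1c[nH]c(C(c2ccc(-c3ccc4cccc(F)c4c3)[nH]c2=O)C(C)C)n1`, has not yet been measured. It differs from compound 2 in one place: a group of 6 heavy atoms (4 carbon, 2 nitrogen; one five-membered aromatic ring with 2 hetero atoms) in place of a group of 8 heavy atoms (4 carbon, 4 nitrogen; one five-membered non-aromatic ring with 2 hetero atoms), on a saturated chain carbon bound to an aromatic carbon and a saturated chain carbon.

Among the measured compounds shown here, only one measured step bears on this change, the step of a 1.1-fold higher number from compound 1 to compound 2 (0.04 log units; within the scatter), and it concerns a different replacement at the same saturated chain carbon. It gives little guidance for a new aromatic group, yet it shows that the shared core of compounds 1 and 2 kept a similar solubility when the group on that carbon was exchanged. On that thin basis, compound 3 is expected to sit close to compound 2, with a step of a 1.3-fold lower number from compound 2 to compound 3 (0.10 log units; within the scatter) that need not exceed the scatter. Compound 3 is therefore estimated at 20000 nM, within a range from 7000 nM to 55000 nM.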

Compound 3, solubility: 15200 nM
Estimate against measurement, compound 3: 1.3-fold (0.12 log units) above; low and high end bracket the measured number.
By their numbers in this assay, from the lowest: compounds 3, 1 and 2 (each within the scatter of the next).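

Among these compounds, compound 3 carries 4-methyl-1H-imidazol-2-yl on the saturated chain carbon, so this position now holds a five-membered aromatic ring as well as the two non-aromatic rings of the earlier compounds. In this assay, among the compounds shown here, replacing the cyano-bearing ring of compound 2 gives a 1.7-fold lower number from compound 2 to compound 3 (0.22 log units; within the scatter) and the comparison with 2-oxopiperidin-1-yl gives a 1.5-fold lower number from compound 1 to compound 3 (0.18 log units; within the scatter), so compounds 1, 2 and 3 cannot be told apart on this read-out, and this now holds for an aromatic group too, which the first pair of non-aromatic rings could not show. No independent measurement accompanies these numbers that would help interpret this result.

As far as these compounds go, it remains open whether a group of a different kind on this carbon, such as a primary amine or a carboxylic acid, would give a step beyond the scatter. Also open, from the compounds shown here alone, is what the methyl contributes, since a comparison with the plain 1H-imidazol-2-yl group or with a longer chain in its place would be needed to separate it from the rest of the ring.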